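Benzyl linker in place of the alkyl chain

A few compounds are considered here, and "the series" means these few. Any claim that something is new, unique, unknown or untested is made for them only; others in the source may bear on it.

Three stilbene hydroxamic acids sharing one core have been measured. Compound 1 `COc1cc(/C=C/c2ccc(OCCCC(=O)NO)cc2)cc(OC)c1` gives 5200 nM in a functional assay on HCT-116 cells (Homo sapiens) for cytotoxicity, read by MTT assay, with a stated time of 48 h; on this read-out higher numbers stand for weaker inhibition and lower numbers for stronger inhibition. Compound 2 `COc1cc(/C=C/c2ccc(OCCCCCC(=O)NO)cc2)cc(OC)c1` gives 4100 nM, the lowest of the three numbers, while compound 3 `COc1cc(/C=C/c2ccc(OCCCCCCCC(=O)NO)cc2)cc(OC)c1` gives 12600 nM. The step of a 1.3-fold lower number from compound 1 to compound 2 (0.10 log units; within the scatter) lies within the scatter, whereas a 3.1-fold higher number from compound 2 to compound 3 (0.49 log units; beyond the scatter) and a 2.4-fold higher number from compound 1 to compound 3 (0.38 log units; beyond the scatter) are modest moves toward weaker inhibition as the chain grows.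

Compound 4 `COc1cc(/C=C/c2ccc(OCc3ccc(C(=O)NO)cc3)cc2)cc(OC)c1` has not yet been measured. Its change from compound 2 is 4-(hydroxycarbamoyl)phenyl in place of 4-(hydroxycarbamoyl)butyl on a saturated chain carbon bound to an oxygen on an aromatic ring. Within the data shown here, none of the measured steps involves a ring in this position; they only show that lengthening the chain past compound 2 raises the number, and shortening it changes nothing beyond the scatter. The new change is of a different kind, so the measured steps give only weak guidance, and no step beyond the scatter is firmly expected in either direction.

On that basis the estimated step is a 1.1-fold higher number from compound 2 to compound 4 (0.04 log units; within the scatter). Compound 4 is therefore expected to give about 4500 nM in this assay, within a range of 1500 nM to 14000 nM.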

Compound 4, half-maximal inhibitory concentration: 10400 nM
Estimate against measurement, compound 4: 2.3-fold (0.36 log units) below; measured number inside the range.
By their numbers in this assay, from the lowest: compounds 2, 1, 4 and 3 (each within the scatter of the next, the first and the last beyond it).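

In this assay, 4-(hydroxycarbamoyl)phenyl in place of 4-(hydroxycarbamoyl)butyl on a saturated chain carbon bound to an oxygen on an aromatic ring gives a 2.5-fold higher number from compound 2 to compound 4 (0.40 log units; beyond the scatter), so this position responds to an aromatic ring as well as to chain length, which the open-chain compounds alone could not show. Among these compounds, the ring does not set compound 4 apart from every chain, however: a 1.2-fold lower number from compound 3 to compound 4 (0.08 log units; within the scatter) and a 2.0-fold higher number from compound 1 to compound 4 (0.30 log units; within the scatter) both stay within the scatter, leaving compound 2 as the only open-chain compound separated from compound 4 by a step beyond it. Nothing available bears on the reason for the step from the butyl to the phenyl group.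

From the compounds shown here alone, whether a carboxylic acid in place of the hydroxycarbamoyl group on the ring would keep compound 4 near its number remains open. So does whether an amine on that ring, or a longer chain carrying it, would bring the number back toward that of compound 2 or move it further away.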